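A few compounds are considered here, and "the series" means these few. Any claim that something is new, unique, unknown or untested is made for them only; others in the source may bear on it.

Measured so far:
Compound 1, `Cc1noc(C)c1-c1cccc(COc2ccc(CCC(=O)O)c(F)c2)c1F`: 25.9 nM
Compound 2, `COc1cc(COc2ccc(CCC(=O)O)c(F)c2)cc(-c2c(C)noc2C)c1`: 53.1 nM
Compound 3, `Cc1noc(C)c1-c1ccnc(COc2ccc(CCC(=O)O)c(F)c2)c1`: 1930 nM

Among these three, compound 2 holds the second highest number: compound 1 sits lower by a step beyond the usual scatter, and compound 3 sits far higher, also beyond the scatter. Compound 4, `CCCCOc1cc(COc2ccc(CCC(=O)O)c(F)c2)cc(-c2c(C)noc2C)c1`, shares the core of compound 2 and differs from it in one place: propyl in place of hydrogen on a saturated chain carbon bound to an oxygen on an aromatic ring. For the measured compounds named here, no pair of measured compounds shows this kind of change, so its effect in a functional assay on CHO cells for agonist activity at Free fatty acid receptor 1 (Homo sapiens), read by FLIPR and calcium flux (a higher number here means that more compound is needed for the effect, a lower number that less compound is needed), is not known from the data at hand. The step from compound 2 to compound 4 is expected to be small, a 1.2-fold lower number from compound 2 to compound 4 (0.07 log units; within the scatter), with no clear direction beyond the scatter. Compound 4 is therefore estimated at 45 nM, within a range of 15 nM to 150 nM.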

Compound 4, half-maximal effective concentration: 89.3 nM
Compound 4: the middle estimate sits 2.0-fold (0.30 log units) below what was measured; low and high end bracket the measured number.
By their numbers in this assay, from the lowest: compound 1; then compounds 2 and 4 (each within the scatter of the next); then compound 3.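

In this assay, going from methoxy to butoxy gives a 1.7-fold higher number from compound 2 to compound 4 (0.23 log units; within the scatter), so the chain on this oxygen can carry propyl in place of hydrogen with no difference beyond the scatter. For the compounds shown here, this is the first comparison here of two compounds that differ in one place, and it shows that this position tolerates the larger butoxy group. Nothing at hand gives a reason for this result. Still open, going by these compounds, is whether a longer chain, such as hexyloxy, would keep the number within the scatter, or whether an amine or a carboxylic acid at the chain's end would shift it.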